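Swapping the naphthalene group for a tert-butylphenyl group

A few compounds are considered here, and "the series" means these few. Any claim that something is new, unique, unknown or untested is made for them only; others in the source may bear on it.

Of the compounds shown here, three sharing the same core have been tested in a functional assay on CCRF-CEM cells (Homo sapiens) for antiproliferative activity, read by MTT assay, with a stated time of 72 h, tested at 100 uM; a higher number here means a weaker effect of the compound at the concentration tested, a lower number a stronger effect. Compound 2 `COC(C(=O)OC(C)Cn1cnc2c1c(=O)n(C)c(=O)n2C)c1ccc2ccccc2c1` gives 27.6% in this assay. Of the three numbers this is the second highest: compound 3 `CC(Cn1cnc2c1c(=O)n(C)c(=O)n2C)OC(=O)Sc1ccccc1` gives 14.5%, a number below that of compound 2 and beyond the scatter, while compound 1 `COC(C(=O)OC(C)Cn1cnc2c1c(=O)n(C)c(=O)n2C)c1cccc2ccccc12` gives 51.4%, the highest of the three. For the measured compounds named here, the only single-point step among the measured compounds is a number 23.8 percentage points lower from compound 1 to compound 2 (beyond the scatter).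

Compound 4 `COC(C(=O)OC(C)Cn1cnc2c1c(=O)n(C)c(=O)n2C)c1ccc(C(C)(C)C)cc1` has not yet been measured. It differs from compound 2 in one place: 4-(tert-butyl)phenyl in place of naphthalen-2-yl on a saturated chain carbon bound to a carbonyl carbon and an oxygen on a saturated carbon. The step from compound 1 to compound 2 is the one that bears on this change, as it too altered the aromatic group at the same place, and it moved the number by a modest amount beyond the scatter. Going by the values given here, that step, however, compared two two-ring groups; no measured step replaces a two-ring group by a one-ring group, so the direction here is open. The change is therefore expected to shift the number by a modest amount at most, with the estimate for compound 4 being 38%, in a range from 18% to 62%. The step from compound 2 to compound 4 is accordingly expected to be a number 10.4 percentage points higher from compound 2 to compound 4 (beyond the scatter).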

Compound 4, a percentage reported as activity, at one concentration (the size of the read-out at that concentration, not a potency): 28.6%
Beside the measured number, compound 4's estimate is 9.4 percentage points above it; measured number inside the range.
By their numbers in this assay, from the lowest: compound 3; then compounds 2 and 4 (each within the scatter of the next); then compound 1.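

In this assay, putting 4-(tert-butyl)phenyl in place of naphthalen-2-yl on this saturated chain carbon gives a number 1 percentage points higher from compound 2 to compound 4 (within the scatter), so at this place a group with one aromatic ring and the same number of heavy atoms cannot be told apart from a group with two, something the earlier comparison of two naphthalene groups could not show. Set against the other naphthalene group, the same one-ring group gives a number 22.8 percentage points lower from compound 1 to compound 4 (beyond the scatter), which leaves naphthalen-1-yl as the group that stands apart among these three closely related esters, while a second aromatic ring as such does not decide the number. Nothing available gives a reason for this result.

On these data alone, what the tert-butyl contributes remains open, since a plain phenyl, or a phenyl ring carrying an amine or a carboxylic acid in its place, would be needed to separate the effect of the tert-butyl from that of the ring. The read-out also comes from a single concentration, so whether these compounds would keep the same relation at other concentrations is not settled.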